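The compounds below may be only part of what the source reports. "The series", "measured", "known", "first", "only" and "open" are said of these compounds alone.

Measured so far:

Compound 1, `COc1ccc(OCC(=O)N2CCN(c3ccc(C(F)(F)F)cc3[C@@H](N)CC(C)C)CC2)cc1`, gives 3800 nM in an assay on HEK293 cells for displacement of a labelled ligand from Melanocortin receptor 4 (Homo sapiens); a lower number here means a stronger inhibitor, a higher number a weaker inhibitor.
Compound 2, `CC(C)C[C@H](N)c1cc(C(F)(F)F)ccc1N1CCN(C(=O)C(C)Cc2ccc(Cl)cc2O)CC1`, gives 36 nM in this assay.
Compound 3, `CC(C)C[C@H](N)c1cc(C(F)(F)F)ccc1N1CCN(C(=O)CCC(N)=O)CC1`, gives only a limit, > 10000 nM, in this assay.

Compound 3 thus stands at the edge of what this assay can report, as the limit of > 10000 nM in this assay, at which 1 of the 3 values shown sits, shows; no number is known for it. Compound 4, `CC(C)C[C@H](N)c1cc(C(F)(F)F)ccc1N1CCN(C(=O)COc2cccc(Cl)c2)CC1`, differs from compound 3 in one place: 3-chlorophenoxy in place of carbamoylmethyl on a saturated chain carbon bound to a carbonyl carbon.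

Among the compounds with values here, two measured steps bear on this change. The step of an at least 2.6-fold higher number from compound 1 to compound 3 (0.42 log units; beyond the scatter) runs the opposite way, an aryloxy group giving way to carbamoylmethyl, and weakened binding. The step of an at least 270-fold higher number from compound 2 to compound 3 (2.44 log units; beyond the scatter) shows that replacing compound 2's side chain with the carbamoyl chain cost a great deal. Going from compound 3 to compound 4 reverses the direction of these steps, so a large fall in the number is expected. Compound 4 resembles compound 1 closely, so its number is expected near compound 1's 3800 nM. For compound 4 the estimate is 2500 nM, between 600 nM and 10000 nM, a step of an at least 4.0-fold lower number from compound 3 to compound 4 (0.60 log units; beyond the scatter).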

Compound 4, inhibition constant: 2600 nM
The estimate for compound 4 lay 1.0-fold (0.02 log units) below the measured number; the range from low to high includes it.
By their numbers in this assay, from the lowest: compound 2; then compounds 4 and 1 (each within the scatter of the next). At a limit, above all of these: compound 3.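

Placing 3-chlorophenoxy on this saturated chain carbon in place of carbamoylmethyl gives an at least 3.8-fold lower number from compound 3 to compound 4 (0.58 log units; beyond the scatter) and so links the carbamoyl chain directly to an aryloxy group. As far as these compounds go, the true size of that step is unknown, as compound 3 gives only a limit of the assay: the limit of > 10000 nM in this assay, at which 1 of the 4 values shown sits. Changing 4-methoxyphenyl to 3-chlorophenyl on the oxygen gives a 1.5-fold lower number from compound 1 to compound 4 (0.16 log units; within the scatter) and so does not separate these two aryloxy groups, while a 72-fold higher number from compound 2 to compound 4 (1.86 log units; beyond the scatter) shows that the (3-chlorophenoxy)methyl group does not match the 1-(4-chloro-2-hydroxybenzyl)ethyl group of compound 2.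

From the compounds shown here alone, how an unsubstituted phenoxy group or a chain ending in an amine or a carboxylic acid would fare here remains open. So does the question of which part of the 1-(4-chloro-2-hydroxybenzyl)ethyl group accounts for the lower number of compound 2.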